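A few compounds are considered here, and "the series" means these few. Any claim that something is new, unique, unknown or untested is made for them only; others in the source may bear on it.

Measured compounds:
Compound 1 `O=[N+]([O-])c1ccc(/C=N/Cc2cccnc2)cc1`: 100 mg/kg
Compound 2 `C(=N/Cc1cccnc1)\c1ccccc1`: 30 mg/kg

In a functional assay on the whole organism (strain Swiss albino) with Mus musculus as the target, in the maximal electroshock model, with a stated time of 4 h (on this read-out lower numbers stand for an effect already at smaller amounts and higher numbers for an effect only at larger amounts of compound), compound 2 has the lowest number of the two, with compound 1 the nearest, as the step of a 3.3-fold lower number from compound 1 to compound 2 (0.52 log units; beyond the scatter) shows. Compound 3 `Clc1ccc(/C=N/Cc2cccnc2)cc1` differs from compound 2 by chloro in place of hydrogen on an aromatic carbon. Among the compounds with values here, only the step from compound 1 to compound 2 touches the same position, and it concerns a different group, so it gives no direct guide; a modest change on its own. Within the data shown here, with no step that carries the same group, the expected change is none beyond the scatter: no change at the digits printed from compound 2 to compound 3 (within the scatter). Compound 3 is estimated at 30 mg/kg, within 10 mg/kg to 100 mg/kg.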

Compound 3, minimum effective dose: 100 mg/kg
Compound 3: middle estimate off by 3.3-fold (0.52 log units), on the low side; the range from low to high includes it.
By their numbers in this assay, from the lowest: compound 2; then compounds 1 and 3 (each within the scatter of the next).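

In this assay, chloro on an aromatic carbon, para to a group of 9 heavy atoms, gives a 3.3-fold higher number from compound 2 to compound 3 (0.52 log units; beyond the scatter) and so, like nitro, goes with a higher number than hydrogen at this place. Exchanging nitro for chloro gives no change at the digits printed from compound 1 to compound 3 (within the scatter) and so does not separate these two groups. Nothing measured here explains this result. The compounds shown leave open whether any group at this place can match or improve on hydrogen, such as a methoxy group, an amine or fluoro.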